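This account rests on a few compounds, and the source may have more. Where it says the series, first, only, none or still open, it means among the compounds named here.

Measured compounds:
compound 1 `c1cc(-c2nccs2)c2c(c1)C(c1ncc[nH]1)CC2`, 64% in a functional assay on CHO cells for agonist activity at Alpha-1A adrenergic receptor (Homo sapiens), read by FLIPR and calcium flux; on this read-out lower numbers stand for smaller maximal responses and higher numbers for larger maximal responses
compound 2 `Cc1oncc1-c1cccc2c1CCC2c1ncc[nH]1`, 63% in this assay
compound 3 `c1ccc(-c2cccc3c2CCC3c2ncc[nH]2)nc1`, 53% in this assay

Compound 3 stands lowest of the three numbers. Against compound 2 the gap is a number 10 percentage points lower from compound 2 to compound 3 (within the scatter); against compound 1 it is a number 11 percentage points lower from compound 1 to compound 3 (beyond the scatter), the only step in the set beyond the scatter. The comparison of compound 1 with compound 2 gives a number 1 percentage points lower from compound 1 to compound 2 (within the scatter).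

Compound 4 `Cn1ccc(-c2cccc3c2CCC3c2ncc[nH]2)n1` differs from compound 3 by 1-methyl-1H-pyrazol-3-yl in place of pyridin-2-yl on an aromatic carbon. All three measured steps are swaps of the aryl group at this same position, and none moved the maximal response by much. The same is expected here: for compound 4 the estimated step is a number 5 percentage points higher from compound 3 to compound 4 (within the scatter), not beyond the scatter. Compound 4 is thus expected at 58%, within 45% to 72%.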

Compound 4, largest response reached (Emax), in percent of the reference or control that the assay uses: 19%
The estimate for compound 4 lay 39 percentage points above the measured number; measured number outside the range, below it.
By their numbers in this assay, from the lowest: compound 4; then compounds 3, 2 and 1 (each within the scatter of the next, the first and the last beyond it).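

In this assay this position proves sensitive to the aryl group: 1-methyl-1H-pyrazol-3-yl gives a number 34 percentage points lower from compound 3 to compound 4 (beyond the scatter) and a number 44 percentage points lower from compound 2 to compound 4 (beyond the scatter) and a number 45 percentage points lower from compound 1 to compound 4 (beyond the scatter) as large steps, although the heavy-atom count of the group stays the same as for pyridin-2-yl. A five-membered aromatic ring alone does not go with a low maximal response, since compound 1 and compound 2 also carry one and stay high. Nothing available accounts for the drop.

Open, going by these compounds, is whether the drop follows the methyl on the pyrazole or the pyrazole ring itself. An unsubstituted pyrazole or a plain phenyl at this carbon would help separate the two.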